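The compounds below may be only part of what the source reports. "The series", "measured", "known", "first", "only" and "open" are said of these compounds alone.

Three compounds built on one shared core were measured in a functional assay on cells for agonist activity at Free fatty acid receptor 1 (Homo sapiens), read by FLIPR and calcium flux, with a stated time of 60 min; a higher number here means a larger maximal response, a lower number a smaller maximal response. Compound 1 `COc1ccc(CCCC(C)(C)C)c(-c2ccc(COc3cccc(C(CC(=O)O)C4CC4)c3)cc2)c1` gives 105%. Compound 2 `COc1ccc(CCCC(C)(C)C)c(N2CCC(COc3cccc(C(CC(=O)O)C4CC4)c3)CC2)c1` gives 106%, the second highest of the three numbers, though all three lie within the usual scatter of one another. Compound 3 `COc1ccc(C)c(N2CCC(COc3cccc(C(CC(=O)O)C4CC4)c3)CC2)c1` gives 113%. Among the measured compounds shown here, the single measured step that bears on the question is a number 7 percentage points higher from compound 2 to compound 3 (within the scatter), where a long chain was removed altogether and the maximal response did not move beyond the scatter. Compound 4 `COc1ccc(C(C)C)c(N2CCC(COc3cccc(C(CC(=O)O)C4CC4)c3)CC2)c1` differs from compound 2 by isopropyl in place of 4,4-dimethylpentyl on an aromatic carbon, a smaller change than that removal. The expected step is therefore none beyond the scatter, a number 2 percentage points higher from compound 2 to compound 4 (within the scatter). Compound 4 is expected to give 108%, with a range from 96% to 120%.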

Compound 4, largest response reached (Emax), in percent of the reference or control that the assay uses: 117%
The estimate for compound 4 lay 9 percentage points below the measured number; the range from low to high includes it.
By their numbers in this assay, from the lowest: compounds 1, 2, 3 and 4 (each within the scatter of the next, the first and the last beyond it).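

Swapping 4,4-dimethylpentyl for isopropyl, para to a methoxy group, produces a change in this assay that clears the usual scatter (a number 11 percentage points higher from compound 2 to compound 4 (beyond the scatter)). Isopropyl in place of methyl at the same position does not separate the two compounds (a number 4 percentage points higher from compound 3 to compound 4 (within the scatter)), so these two small groups cannot be told apart here. Nothing shown explains why the maximal response differs.

Still open, on these data alone, is how a tert-butyl group, a shorter chain such as ethyl, or an amine at this position would read in this assay. As far as these compounds go, the same swap on the core of compound 1 also remains open.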